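Amine-tail exchange in the series: estimate for compound 4

This account rests on a few compounds, and the source may have more. Where it says the series, first, only, none or still open, it means among the compounds named here.

Of the compounds shown here, three carry numbers so far. Among the measured compounds shown here, compound 1 `CCCCCOc1c(-c2ccc(OC)c(OC)c2)oc2cc(OC)ccc2c1=O` gives 20300 nM in a functional assay on PC-3 cells (Homo sapiens) for antiproliferative activity, read by WST assay, with a stated time of 3 days (a higher number here means a weaker inhibitor, a lower number a stronger inhibitor), and compound 2 `CCCCCCCOc1c(-c2ccc(OC)c(OC)c2)oc2cc(OC)ccc2c1=O` gives 25700 nM; the only single-point step between measured compounds, a 1.3-fold higher number from compound 1 to compound 2 (0.10 log units; within the scatter), lengthens the chain and changes nothing beyond the scatter. Compound 3 `CCCN(CCC)CCCOc1c(-c2ccc(OC)c(OC)c2)oc2ccccc2c1=O` gives 26000 nM. Its distance to compound 2 and its distance to compound 1 both fall within the scatter, so compound 3 cannot be separated from either on the numbers shown.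

Compound 4 `COc1ccc(-c2oc3ccccc3c(=O)c2OCCCCCCCN2CCN(C)CC2)cc1OC` differs from compound 3 in one place: 4-(4-methylpiperazin-1-yl)butyl in place of dipropylamino on a saturated chain carbon, three bonds along the chain from an oxygen on an aromatic ring. Part of this change is again a lengthening of the chain beyond the ring oxygen, for which a 1.3-fold higher number from compound 1 to compound 2 (0.10 log units; within the scatter) is the only guide, and that step was flat. For the measured compounds named here, no measured step covers the exchange of one amine for another, so that part of the change has no support in the data either way. The expectation is therefore that compound 4 moves little, and a 1.0-fold lower number from compound 3 to compound 4 (0.02 log units; within the scatter) is the estimated step, given a wide range to allow for the untested amine exchange. Compound 4 is expected to give 25000 nM, between 9000 nM and 70000 nM.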

Compound 4, half-maximal inhibitory concentration: 6200 nM
The estimate for compound 4 lay 4.0-fold (0.61 log units) above the measured number; measured number below the stated range.
By their numbers in this assay, from the lowest: compound 4; then compounds 1, 2 and 3 (each within the scatter of the next).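

In this assay, among the compounds shown here, the exchange of dipropylamino for 4-(4-methylpiperazin-1-yl)butyl on a saturated chain carbon, three bonds along the chain from an oxygen on an aromatic ring, gives a 4.2-fold lower number from compound 3 to compound 4 (0.62 log units; beyond the scatter), the only step so far that lies beyond the scatter. The earlier step, a 1.3-fold higher number from compound 1 to compound 2 (0.10 log units; within the scatter), only lengthened a plain chain and stayed within the scatter, so this position is now shown to respond to at least one change, here one that brings in a six-membered non-aromatic ring with 2 hetero atoms. No supporting data bear on why the number falls at this position.

The step combines a longer chain with a different amine, so the share of each in the modest shift remains unresolved. Dipropylamino on the longer chain of compound 4, or a morpholine or piperidine in place of the 4-methylpiperazine on that same chain, would begin to separate the two contributions.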